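Benzyl Ether in Place of Chlorobenzoate on a Second Core

The compounds below may be only part of what the source reports. "The series", "measured", "known", "first", "only" and "open" are said of these compounds alone.

Measured compounds:
compound 1, `CC1=CC[C@H]2[C@H](CC[C@]2(C)O)C(C)(C)[C@@H]1CC[C@H]1[C@]2(C)CC[C@H](OC(=O)c3ccc(Cl)cc3)C(C)(C)O[C@H]2CC[C@@]1(C)O`, 10300 nM
compound 2, `CC1=CC[C@H]2[C@@H]1CC=C(C)[C@@H](CC[C@H]1[C@]3(C)CC[C@H](OC(=O)c4ccc(Cl)cc4)C(C)(C)O[C@H]3CC[C@@]1(C)O)C2(C)C`, 12700 nM
compound 3, `CC1=CC[C@H]2[C@H](CC[C@]2(C)O)C(C)(C)[C@@H]1CC[C@H]1[C@]2(C)CC[C@H](OCc3ccccc3)C(C)(C)O[C@H]2CC[C@@]1(C)O`, 29100 nM

In a functional assay on MDA-MB-231 cells (Homo sapiens) for antiproliferative activity, read by MTT assay, with a stated time of 72 h (on this read-out lower numbers stand for stronger inhibition and higher numbers for weaker inhibition), compound 1 gives 10300 nM, compound 2 gives 12700 nM and compound 3 gives 29100 nM. Compound 3 differs from compound 1 by benzyl in place of (4-chlorophenyl)carbonyl on an oxygen on a saturated carbon, and this change gave a 2.8-fold higher number from compound 1 to compound 3 (0.45 log units; beyond the scatter). Compound 1 and compound 2 carry the same ester on different cores; the difference between the two cores is not broken down here, and their two numbers lie within the scatter of each other.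

Compound 4, `CC1=CC[C@H]2[C@@H]1CC=C(C)[C@@H](CC[C@H]1[C@]3(C)CC[C@H](OCc4ccccc4)C(C)(C)O[C@H]3CC[C@@]1(C)O)C2(C)C`, is not yet measured. It differs from compound 2 by benzyl in place of (4-chlorophenyl)carbonyl on an oxygen on a saturated carbon, the same change as from compound 1 to compound 3, made at the same place. The step is expected to be a 2.6-fold higher number from compound 2 to compound 4 (0.41 log units; beyond the scatter) in this assay. This expectation rests on the earlier step, because the same change gave a 2.8-fold higher number from compound 1 to compound 3 (0.45 log units; beyond the scatter). Compound 4 is therefore estimated at 33000 nM, expected between 15000 nM and 75000 nM.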

Compound 4, half-maximal inhibitory concentration: 35700 nM
Compound 4: the middle estimate sits 1.1-fold (0.03 log units) below what was measured, within the range that was stated.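

In this assay, benzyl in place of (4-chlorophenyl)carbonyl on the second core gave a 2.8-fold higher number from compound 2 to compound 4 (0.45 log units; beyond the scatter). The step carried over from one core to the other with its size intact: the same change on two cores in this assay, a 2.8-fold higher number (0.45 log units; beyond the scatter) from compound 1 to compound 3 and a 2.8-fold higher number (0.45 log units; beyond the scatter) from compound 2 to compound 4, 1.0-fold (0.00 log units) apart, within the scatter of two such steps. This shows that the change transfers between these two cores in this one assay, but it does not show that it would transfer to any further core, or whether the carbonyl or the chlorine accounts for the step.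

The compounds shown leave open how a benzoyl group or a chlorobenzyl group would behave on the same oxygen, which could separate those two parts of the change. As far as these compounds go, how an amine or a carboxylic acid at that place would read also remains open.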